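This account rests on a few compounds, and the source may have more. Where it says the series, first, only, none or still open, it means among the compounds named here.

Measured in a functional assay on MCF7 cells (Homo sapiens) for cytotoxicity, read by cell counting, with a stated time of 48 h; a higher number here means a weaker inhibitor, a lower number a stronger inhibitor:
Compound 1 `Clc1ccc(-n2cc(COc3cccc4cnc(Nc5cccc(Cl)c5)nc34)nn2)cc1`: > 25000 nM (a limit of the assay, not a number)
Compound 2 `COc1ccccc1-n1cc(COc2cccc3cnc(Nc4cccc(Cl)c4)nc23)nn1`: 6000 nM

Among the compounds with values here, compound 2 holds the only exact number so far. Compound 1 is reported only as a limit, (the limit of > 25000 nM in this assay, at which 1 of the 2 values shown sits).

Compound 3 `Clc1cccc(Nc2ncc3cccc(OCc4cn(Cc5c(Cl)cccc5Cl)nn4)c3n2)c1` keeps the shared core and changes one group: 2,6-dichlorobenzyl in place of 2-methoxyphenyl on an aromatic nitrogen. Within the data shown here, the one measured step concerns the same nitrogen, with 2-methoxyphenyl in place of 4-chlorophenyl: an at least 4.1-fold lower number from compound 1 to compound 2 (0.61 log units; beyond the scatter). That single step shows that this assay can respond to a change at this place. Compound 3 loses the 2-methoxyphenyl and, like compound 1, carries chlorine, so a moderately higher number, meaning a weaker inhibitor, is expected: a 2.3-fold higher number from compound 2 to compound 3 (0.37 log units; beyond the scatter). This is a cautious expectation, as it rests on one step and the new group is a benzyl. For compound 3 the estimate is 14000 nM, expected to fall between 5000 nM and 25000 nM.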

Compound 3, half-maximal inhibitory concentration: 6000 nM
Beside the measured number, compound 3's estimate is 2.3-fold (0.37 log units) above it, within the range that was stated.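

In this assay, the group on the aromatic nitrogen need not be the 2-methoxyphenyl for the number to stay low: 2,6-dichlorobenzyl in its place gives no change at the digits printed from compound 2 to compound 3 (within the scatter). Chlorine on this group therefore does not by itself go with a weak result, as compound 1 and compound 3 both carry it, yet the change of group gives an at least 4.1-fold lower number from compound 1 to compound 3 (0.61 log units; beyond the scatter). Compound 1 is a limit and not a number, so the true size of that step stays unknown: the limit of > 25000 nM in this assay, at which 1 of the 3 values shown sits.

From the compounds shown here alone, in compound 3 the benzyl link and the two chlorines enter together, and their separate shares stay unknown. Going by these compounds, it also remains open how this assay would respond to an amine, a carboxylic acid or a longer chain on the same nitrogen.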